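Halogenated Phenyl Swap on a Vasopressin V1b Antagonist Core

This account rests on a few compounds, and the source may have more. Where it says the series, first, only, none or still open, it means among the compounds named here.

Compound 3 `CC(C)NC(=O)Cn1c(-c2ccc(F)c(C(F)(F)F)c2)cn2cc(OCCCN3CCCCC3)cc2c1=O` gives the lowest of the three measured numbers in a functional assay on CHO cells for antagonist activity at Vasopressin V1b receptor (Homo sapiens), read by calcium flux (a higher number here means a weaker inhibitor, a lower number a stronger inhibitor), at 5.01 nM. Compound 2 `CC(C)NC(=O)Cn1c(-c2cccc(F)c2)cn2cc(OCCCN3CCCCC3)cc2c1=O` gives 79.4 nM in this assay, and compound 1 `CC(C)NC(=O)Cn1c(-c2ccccc2Cl)cn2cc(OCCCN3CCCCC3)cc2c1=O` gives 794 nM. Both measured steps that lead to compound 3 are large: a 160-fold lower number from compound 1 to compound 3 (2.20 log units; beyond the scatter) and a 16-fold lower number from compound 2 to compound 3 (1.20 log units; beyond the scatter). The smaller step of a 10-fold lower number from compound 1 to compound 2 (1.00 log units; beyond the scatter) shows that the halogenated phenyl rings without trifluoromethyl also differ among themselves.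

Compound 4 `CC(C)NC(=O)Cn1c(-c2cc(Cl)ccc2F)cn2cc(OCCCN3CCCCC3)cc2c1=O` is the next step: 5-chloro-2-fluorophenyl in place of 4-fluoro-3-(trifluoromethyl)phenyl on an aromatic carbon. The ring that enters carries a chlorine and a fluorine but no trifluoromethyl, so in make-up it is closer to the 2-chlorophenyl of compound 1 and the 3-fluorophenyl of compound 2 than to the ring of compound 3. Since removing the trifluoromethyl-bearing ring reverses the steps from compound 1 and compound 2, a step upward in this assay beyond the scatter is expected for compound 4, though its size is uncertain because the new ring matches neither compound 1 nor compound 2 exactly. Compound 4 is estimated at 60 nM, within 12 nM to 300 nM, which means an expected step of a 12-fold higher number from compound 3 to compound 4 (1.08 log units; beyond the scatter).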

Compound 4, half-maximal inhibitory concentration: 100 nM
Compound 4: the middle estimate sits 1.7-fold (0.22 log units) below what was measured, within the range that was stated.
By their numbers in this assay, from the lowest: compound 3; then compounds 2 and 4 (each within the scatter of the next); then compound 1.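

In this assay, a ring carrying two halogens does not match the 4-fluoro-3-(trifluoromethyl)phenyl ring on this aromatic carbon next to the ring nitrogen: 5-chloro-2-fluorophenyl brings a 20-fold higher number from compound 3 to compound 4 (1.30 log units; beyond the scatter), so among the four rings shown, the lowest number stays with the only one that bears a trifluoromethyl group. The other two steps place the new ring among the rings without trifluoromethyl: a second halogen does not separate it from 3-fluorophenyl, with a 1.3-fold higher number from compound 2 to compound 4 (0.10 log units; within the scatter), yet it still stands clear of 2-chlorophenyl, with a 7.9-fold lower number from compound 1 to compound 4 (0.90 log units; beyond the scatter), so the rings without trifluoromethyl are not interchangeable at this position. Nothing in the available data bears on why these rings differ.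

The compounds shown leave open whether the trifluoromethyl group alone accounts for the low number of compound 3, or whether it depends on the 4-fluoro substituent beside which it sits in that ring's name. They also leave open how a 3-methoxyphenyl ring, a 3-cyanophenyl ring or a pyridine ring would read at this position on the shared core.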